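Chloro in Place of Methoxy: From Compound 1 to Compound 4

A few compounds are considered here, and "the series" means these few. Any claim that something is new, unique, unknown or untested is made for them only; others in the source may bear on it.

Of the compounds shown here, three have been measured in a functional assay on MIA PaCa-2 cells (Homo sapiens) for inhibition, read by MTT assay, with a stated time of 72 h; on this read-out higher numbers stand for weaker inhibition of growth and lower numbers for stronger inhibition of growth. Compound 1 `COc1ccc(S(=O)(=O)NCCCCCCNCc2ccc(Br)cc2)cc1` gives 13000 nM, the second highest of the three numbers. Compound 3 `CC(C)(C)c1ccc(CNCCNS(=O)(=O)c2cc(C(F)(F)F)cc(C(F)(F)F)c2)cc1` sits nearest with 15000 nM, a gap within the scatter, while compound 2 `COc1ccc(CNCCCNS(=O)(=O)c2cc(C(F)(F)F)cc(C(F)(F)F)c2)cc1` is furthest with 2500 nM, a gap beyond it. Compound 4 `O=S(=O)(NCCCCCCNCc1ccc(Br)cc1)c1ccc(Cl)cc1` has not yet been measured. It differs from compound 1 in one place: chloro in place of methoxy on an aromatic carbon. Going by the values given here, no measured pair isolates this change, so the expectation rests on the change alone. The step of a 1.3-fold lower number from compound 1 to compound 4 (0.11 log units; within the scatter) is expected to be small, in this assay most likely nothing beyond the scatter, with a slight lean toward a lower number. For compound 4 the estimate is 10000 nM, with a range from 4000 nM to 25000 nM.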

Compound 4, concentration for 50% growth inhibition: 5900 nM
Estimate against measurement, compound 4: 1.7-fold (0.23 log units) above, and the stated range covers the measured number.
By their numbers in this assay, from the lowest: compound 2; then compound 4; then compounds 1 and 3 (each within the scatter of the next).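

In this assay chloro in place of methoxy gives a 2.2-fold lower number from compound 1 to compound 4 (0.34 log units; beyond the scatter) on the shared core, a modest step. Going by these compounds alone, this is the first sign that this position, on an aromatic carbon para to a large group, answers to a single change, which the earlier compounds, differing in more than one place, could not show. No evidence is at hand that accounts for the step.

As far as these compounds go, whether fluoro, a nitrile or an amine here would move the number further remains open. So does whether the step holds with a shorter chain.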